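A few compounds are considered here, and "the series" means these few. Any claim that something is new, unique, unknown or untested is made for them only; others in the source may bear on it.

Measured so far:
compound 1 `COc1cncc(N2C[C@H]3CCNC[C@H]32)c1`, 1110 nM
compound 2 `Clc1ccc(N2CC[C@H]3CN[C@H]3C2)nn1`, 78.3 nM

In a functional assay on HEK293 cells for agonist activity at Neuronal acetylcholine receptor; alpha4/beta2 (Homo sapiens), read by FLIPR (a lower number here means that less compound is needed, a higher number that more compound is needed for the effect), compound 2 stands at the lowest of the two numbers; the nearest is compound 1, at a value beyond the scatter above it. Compound 3 `Clc1ccc(N2CC[C@@H]3CN[C@@H]3C2)nn1` is not yet measured. It differs from compound 2 in that (the two compounds have the same atoms and bonds and differ only in configuration as drawn: 2 of 2 stereo elements differ (all stereocentres are inverted: mirror images); a stereocentre at a saturated ring carbon is drawn S in compound 2 and R in compound 3; a stereocentre at a saturated ring carbon is drawn R in compound 2 and S in compound 3). For the measured compounds named here, no step between two measured compounds is at hand to size this change, and nothing shows how a mirror image fares here. Compound 3 is therefore expected to need more compound than compound 2, the step of a 7.7-fold higher number from compound 2 to compound 3 (0.88 log units; beyond the scatter) being beyond the scatter, with an estimate of 600 nM and a range from 80 nM to 5000 nM.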

Compound 3, half-maximal effective concentration: 359 nM
For compound 3 the middle estimate is 1.7-fold (0.22 log units) above the measured one; the range from low to high includes it.
By their numbers in this assay, from the lowest: compound 2; then compound 3; then compound 1.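

In this assay, the mirror-image pair gives the first measure of what configuration alone is worth on this core, with a 4.6-fold higher number from compound 2 to compound 3 (0.66 log units; beyond the scatter). The assay therefore distinguishes the two mirror images, although compound 3 keeps a number below that of compound 1, a compound with a different structure. The gap can be assigned to configuration because nothing else changes: the fact that compounds 2 and 3 differ only in the configuration as drawn. The compounds shown leave open whether a gap of this size would persist with an amine or a nitrile in place of the chlorine. They also leave open how the mirror image of compound 1 would fare.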